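Adding a carboxy end to compound 2

The compounds below may be only part of what the source reports. "The series", "measured", "known", "first", "only" and "open" are said of these compounds alone.

Measured so far in a functional assay on K562 cells (Homo sapiens) for cytotoxicity, read by trypan blue exclusion, with a stated time of 96 h; a lower number here means a stronger inhibitor, a higher number a weaker inhibitor:
compound 1 `COc1ccc(CS(=O)(=O)/C=C/c2cc(OC)c(OC)c(OC)c2)cc1N` gives 250 nM here
compound 2 `COC(=O)CNc1cc(CS(=O)(=O)/C=C/c2cc(OC)c(OC)c(OC)c2)ccc1OC` gives 30000 nM here

Compound 2 has the higher of the two numbers, at 30000 nM in this test. Compound 3 `COc1ccc(CS(=O)(=O)/C=C/c2cc(OC)c(OC)c(OC)c2)cc1NCC(=O)O` differs from it by hydrogen in place of methyl on an oxygen next to a carbonyl group with hydrogen in place of methyl on an oxygen next to a carbonyl group, so methoxycarbonyl becomes carboxy. Within the data shown here, one measured step bears on this, a 120-fold higher number from compound 1 to compound 2 (2.08 log units; beyond the scatter) on gaining the whole (methoxycarbonyl)methyl. That step does not test the methyl alone, so a smaller move toward a lower number is expected, with wide uncertainty. The expected move is a 6.0-fold lower number from compound 2 to compound 3 (0.78 log units; beyond the scatter) in this estimate. Compound 3 is estimated at 5000 nM with an expected range of 400 nM to 50000 nM in this assay for now.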

Compound 3, half-maximal inhibitory concentration: 3000 nM
Estimate against measurement, compound 3: 1.7-fold (0.22 log units) above; the range from low to high includes it.
By their numbers in this assay, from the lowest: compound 1; then compound 3; then compound 2.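

Losing only the methyl of the ester gives a 10-fold lower number from compound 2 to compound 3 (1.00 log units; beyond the scatter) in this assay and so shows that the end of the chain on this nitrogen counts, not merely the presence of a chain. Carboxymethyl still does not match plain hydrogen on the nitrogen, with a 12-fold higher number from compound 1 to compound 3 (1.08 log units; beyond the scatter) remaining between them. Nothing measured here explains either step.

Still open, on these data alone, is how a longer chain ending in a carboxylic acid, or a primary amide in place of the carboxy end, would fare. Also open, as far as these compounds go, is whether a plain methyl on this nitrogen would already raise the number.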